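The compounds below may be only part of what the source reports. "The series", "measured", "known", "first", "only" and "open" are said of these compounds alone.

Measured compounds in a functional assay on cells (Cancer cell lines, Homo sapiens) for cytotoxicity, read by sulforhodamine B assay, with a stated time of 48 h; on this read-out lower numbers stand for stronger inhibition of growth and higher numbers for weaker inhibition of growth:
- compound 1 `COc1ccc(C2=NN(C3=NC(=O)/C(=C4\C(=O)Nc5ccccc54)S3)C(c3ccc(OC)cc3)C2)cc1` gives 43900 nM
- compound 2 `COc1ccc(C2=NN(C3=NC(=O)/C(=C4\C(=O)Nc5ccc(Br)cc54)S3)C(c3ccc(OC)cc3)C2)cc1` gives 200 nM

Going by the values given here, compound 2 holds the lower of the two numbers in this assay; the only other measured compound is compound 1, which sits far above it. Among the compounds with values here, the one measured step, a 220-fold lower number from compound 1 to compound 2 (2.34 log units; beyond the scatter), joins them: exchanging hydrogen for bromo on the aromatic carbon brought a large drop in the number.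

Compound 3 `COc1ccc(C2=NN(C3=NC(=O)/C(=C4\C(=O)Nc5ccc(Cl)cc54)S3)C(c3ccc(OC)cc3)C2)cc1` is not yet measured. It differs from compound 2 by chloro in place of bromo on an aromatic carbon. The step from compound 1 to compound 2 bears on this only indirectly: it shows that a substituent at this aromatic carbon matters greatly compared with hydrogen, but it says nothing about one such substituent against another. Within the data shown here, no measured pair shows a chloro-for-bromo exchange, so the size of that exchange is unknown here.

Given that compound 3 keeps a substituent where compound 2 has bromo, compound 3 is expected to stay near compound 2, with a step of a 1.8-fold higher number from compound 2 to compound 3 (0.24 log units; within the scatter) that lies within the scatter or only slightly beyond it. The estimate for compound 3 in this assay is 350 nM, with a range from 120 nM to 1200 nM.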

Compound 3, concentration for 50% growth inhibition: 200 nM
Compound 3: middle estimate off by 1.8-fold (0.24 log units), on the high side; the range from low to high includes it.
By their numbers in this assay, from the lowest: compounds 2 and 3 (each within the scatter of the next); then compound 1.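

In this assay, the exchange of bromo for chloro on the aromatic carbon, which stands meta to a fused ring and para to a fused ring, gives no change at the digits printed from compound 2 to compound 3 (within the scatter), so the two substituents cannot be told apart at this position. Chloro in place of hydrogen gives a 220-fold lower number from compound 1 to compound 3 (2.34 log units; beyond the scatter), which matches the step with bromo, a 220-fold lower number from compound 1 to compound 2 (2.34 log units; beyond the scatter), and shows that the large drop in the number is not tied to bromo alone but is shared by the two halogens shown here. Nothing at hand explains this shared drop or the lack of a difference between chloro and bromo.

The compounds shown leave open whether the low number requires a halogen at this carbon, or whether fluoro, a methyl group, an amine or a carboxylic acid placed there would also bring the number down from that of compound 1. They also leave open whether chloro or bromo would have a comparable effect on any other carbon of this ring, since every substituted compound here carries its halogen on the same one.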